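Swapping the Thiazole for a Phenyl on a Spirocyclic Amide

The compounds below may be only part of what the source reports. "The series", "measured", "known", "first", "only" and "open" are said of these compounds alone.

Of the compounds shown here, two have so far been measured in a functional assay on HEK293 cells for antagonist activity at Orexin receptor type 2 (Homo sapiens), read by FLIPR and calcium flux; on this read-out higher numbers stand for higher potency (the scale is a negative logarithm) and lower numbers for lower potency. Compound 1, `O=C(c1cc(Cl)ccc1-c1ncccn1)N1CC2(CC2)C[C@H]1CNc1cc(C(F)(F)F)ccn1`, gives 7.1. Compound 2, `Cc1ccc(-c2nccs2)c(C(=O)N2CC3(CC3)C[C@H]2CNc2ccc(C(F)(F)F)cn2)n1`, gives 8. Of these two numbers, compound 2 stands at the top, and its nearest neighbour, compound 1, sits lower by a gap that lies beyond the usual scatter of repeated measurements.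

Compound 3, `Cc1ccc(-c2ccccc2)c(C(=O)N2CC3(CC3)C[C@H]2CNc2ccc(C(F)(F)F)cn2)n1`, has not yet been measured in this assay. It differs from compound 2 in a single place: phenyl in place of 1,3-thiazol-2-yl on an aromatic carbon. In words, a phenyl takes the place of the 1,3-thiazol-2-yl on an aromatic carbon. For the measured compounds named here, no pair of measured compounds shows this particular change, so nothing in the two known values tells how large its effect will be or which way it will run.

For compound 3 the expected step of a number 0.40 log units lower from compound 2 to compound 3 (beyond the scatter) is a modest loss, close to the edge of the scatter. The estimate for compound 3 in this assay is 7.6, within a range from 6.9 to 8.3.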

Compound 3, negative logarithm of the antagonist equilibrium constant: 8
Compound 3: middle estimate off by 0.40 log units, on the low side, within the range that was stated.
By their numbers in this assay, from the lowest: compound 1; then compounds 2 and 3 (each within the scatter of the next).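

In this assay, for the compounds shown here, putting phenyl in place of 1,3-thiazol-2-yl gives no change at the digits printed from compound 2 to compound 3 (within the scatter), the first reading of any change at this aromatic carbon, which is ortho to a large group and para to a methyl group. The entering ring differs in kind from the one it replaces: the 1,3-thiazol-2-yl is a five-membered aromatic ring with 2 hetero atoms and 2 hydrogen-bond acceptors, while phenyl is a six-membered aromatic ring of carbon only with 0 hydrogen-bond acceptors, and on this core the read-out does not separate the two. No measurement here explains why the two values match, so this pair records the outcome but not its cause.

From the compounds shown here alone, it remains open whether a group that is not an aromatic ring, such as a methyl, an amine or a carboxylic acid, would give a similar value at this carbon. A single pair also cannot say whether the same exchange would run the same way on a different core, such as that of compound 1.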